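This account rests on a few compounds, and the source may have more. Where it says the series, first, only, none or still open, it means among the compounds named here.

Measured compounds:
compound 1, `CC(=O)O[C@@H]1C[C@@H](C)[C@](O)(CCc2ccoc2)[C@@]2(C)CCCC(C)(C)[C@H]12` — < 5 ug/mL
compound 2, `CO[C@H]1C[C@@]2(CC[C@@]3(O2)[C@H](C)CC[C@H]2C(C)(C)[C@@H](OC(C)=O)CC[C@@]23C)[C@H](OC)O1` — < 5 ug/mL
compound 3, `CC(=O)O[C@@H]1C[C@@H](C)[C@]2(CC[C@]3(COC(=O)C3)O2)[C@@]2(C)CCCC(C)(C)[C@H]12` — < 5 ug/mL

In a functional assay on HCT-116 cells (Homo sapiens) for cytotoxicity, read by MTT assay, with a stated time of 72 h (on this read-out lower numbers stand for stronger inhibition and higher numbers for weaker inhibition), compound 1 gives < 5 ug/mL, which is a limit of the assay and not a number. Compound 2 likewise reaches only the limit < 5 ug/mL. Compound 3 gives < 5 ug/mL, again a limit and not a number. Going by the values given here, all three values therefore sit at the limit of < 5 ug/mL in this assay, at which 3 of the 3 values shown sit, so compound 3 cannot be placed above or under the other two on this read-out, and no step between measured compounds can be drawn from these data.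

The next compound, compound 4, `C[C@@H]1C[C@@H](O)[C@H]2C(C)(C)CCC[C@]2(C)[C@@]12CC[C@]1(COC(=O)C1)O2`, differs from compound 3 in one place: hydrogen in place of acetyl on an oxygen on a saturated carbon. Among the compounds with values here, no measured step speaks to what such a change does here, and the shared limit gives no scale to work from. The step from compound 3 to compound 4 in this assay is expected to be a number no lower from compound 3 to compound 4 (the limit leaves the size open), that is, nothing beyond the usual scatter in either direction, with the true value of compound 3 itself unknown under its limit. On that basis compound 4 is expected to give about 5 ug/mL in this assay, within a range from 1.5 ug/mL to 15 ug/mL, with a fair chance that the assay again reports only a limit.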

Compound 4, half-maximal inhibitory concentration: < 5 ug/mL
Compound 4 ended at the assay's limit; the forecaster's own chance of this, stated with the estimate: 45%; the middle value sits exactly at the limit.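

In this assay compound 4 gives < 5 ug/mL, a limit of the assay and not a number. Compound 3 also stands at a limit, so the acetoxy to hydroxy step between compound 3 and compound 4 cannot be read: the limit of < 5 ug/mL in this assay, at which 4 of the 4 values shown sit.

The compounds shown leave open how these compounds truly rank and what that change does on this read-out.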